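Fluoro in place of iodo: a small step expected

The source may report more compounds than this note shows. Statements on the series, on what has been measured and on what is new or still open speak of the compounds shown alone.

In a functional assay on MOLT-4 cells (Homo sapiens) for inhibition (a lower number here means a stronger inhibitor, a higher number a weaker inhibitor), compound 1 (`O=C1O/C(=C\Cn2cc(I)c(=O)[nH]c2=O)C(OCc2ccccc2)=C1OCc1ccccc1`) gives 3900 nM and stands level with compound 3 (`O=C1O/C(=C\Cn2cc(Br)c(=O)[nH]c2=O)C(OCc2ccccc2)=C1OCc1ccccc1`) at 3900 nM here, while compound 2 (`O=C1O/C(=C\Cn2cc(Cl)c(=O)[nH]c2=O)C(OCc2ccccc2)=C1OCc1ccccc1`) gives 6100 nM within the scatter of both. Compound 4 (`O=C1O/C(=C\Cn2cc(F)c(=O)[nH]c2=O)C(OCc2ccccc2)=C1OCc1ccccc1`) has fluoro in place of iodo on an aromatic carbon. Two measured swaps bear on this change: chloro for iodo gave a 1.6-fold higher number from compound 1 to compound 2 (0.19 log units; within the scatter) and bromo for iodo gave no change at the digits printed from compound 1 to compound 3 (within the scatter) on the same aromatic carbon. A step within the scatter is therefore expected, estimated as a 1.3-fold lower number from compound 1 to compound 4 (0.11 log units; within the scatter) in this case. Going by the values given here, no fluoro compound has been measured yet, so the range stays wide. For compound 4 the estimated value is 3000 nM (expected range 600 nM to 8000 nM).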

Compound 4, half-maximal inhibitory concentration: 10900 nM
Compound 4: the middle estimate sits 3.6-fold (0.56 log units) below what was measured; measured number above the stated range.
By their numbers in this assay, from the lowest: compounds 1, 3, 2 and 4 (each within the scatter of the next, the first and the last beyond it).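

Changing the halogen on this aromatic carbon can shift the result after all in this assay: fluoro gives a 2.8-fold higher number from compound 1 to compound 4 (0.45 log units; beyond the scatter) and a 2.8-fold higher number from compound 3 to compound 4 (0.45 log units; beyond the scatter). Compound 4 stays close to the chloro compound, however, with a 1.8-fold higher number from compound 2 to compound 4 (0.25 log units; within the scatter), so fluoro separates clearly only from the iodo and bromo compounds. No available evidence explains this difference.

The compounds shown carry only halogens at this position. A hydrogen, a methyl group, a nitrile or an amine on the same carbon could show whether the trend extends beyond halogens.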